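Working notes: nitro in place of cyano

A few compounds are considered here, and "the series" means these few. Any claim that something is new, unique, unknown or untested is made for them only; others in the source may bear on it.

- compound 1 `O=C1NC(=O)N(/N=C/c2ccc(-c3ccc(Cl)c(Cl)c3)o2)C1O` gives 10 mg/kg as its value
- compound 2 `N#Cc1ccc(-c2ccc(/C=N/N3C(=O)NC(=O)C3O)o2)cc1` gives 96 mg/kg as its value
- compound 3 `O=C1NC(=O)N(/N=C/c2ccc(-c3cccc(C(F)(F)F)c3)o2)C1O` gives 85 mg/kg as its value

In an ADME assay on the whole organism (muscle tissue) for activation, with Mus musculus as the target, in the rotarod test, with a stated time of 30 min (on this read-out higher numbers stand for an effect only at larger amounts of compound and lower numbers for an effect already at smaller amounts), compound 2 at 96 mg/kg and compound 3 at 85 mg/kg lie within the scatter of each other, and both sit at the upper end of the three numbers. Compound 1 at 10 mg/kg lies beyond the scatter from compound 2, on the low side.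

The open case is compound 4 `O=C1NC(=O)N(/N=C/c2ccc(-c3ccc([N+](=O)[O-])cc3)o2)C1O` which carries nitro in place of cyano on an aromatic carbon, para to a large group (nitro in place of cyano on an aromatic carbon). Going by the values given here, no two measured compounds differ in one place only, so no measured step speaks directly to this change. Compound 2 at 96 mg/kg already sits at the upper end, while compound 1 at 10 mg/kg shows that much smaller doses occur in this set. A moderate move toward a lower number is therefore expected, though a result within the scatter of compound 2 remains possible. The expected step of a 2.1-fold lower number from compound 2 to compound 4 (0.33 log units; beyond the scatter) is only a rough estimate. For compound 4 the estimated value is 45 mg/kg with 12 mg/kg to 130 mg/kg as the expected range.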

Compound 4, dose for half-maximal effect: 171 mg/kg
Compound 4: middle estimate off by 3.8-fold (0.58 log units), on the low side; the whole stated range lies below it.
By their numbers in this assay, from the lowest: compound 1; then compounds 3, 2 and 4 (each within the scatter of the next).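

In this assay the exchange of cyano for nitro on an aromatic carbon, para to a large group, gives a 1.8-fold higher number from compound 2 to compound 4 (0.25 log units; within the scatter) and is the only step among the compounds shown that differs in one place. It shows that, at this position, the two groups cannot be told apart on this read-out, even though nitro enters with more heavy atoms and hydrogen-bond acceptors than cyano, which leaves. The earlier compounds could not show this, since none of their pairs isolates a single change, and no measurement at hand explains why compound 2 and compound 4 read alike.

Going by these compounds alone, still open is how a clearly different group at the same position, such as an amine or a carboxylic acid, would compare with cyano in this assay when it is the only change from compound 2. Also open, from the compounds shown here alone, is whether nitro in place of cyano would again stay within the scatter at another place on the six-membered aromatic ring, as one step cannot show whether this holds beyond this single pair.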